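A few compounds are considered here, and "the series" means these few. Any claim that something is new, unique, unknown or untested is made for them only; others in the source may bear on it.

Two measured compounds share one core. Among the compounds with values here, compound 1 `O=C(Nc1cccc(-c2oc3cc(-c4ccc(F)cc4)ccc3c(=O)c2O)c1)c1cccc(F)c1` gives 6590 nM in a functional assay on HCC1937 cells (Homo sapiens) for antiproliferative activity, read by CCK-8 assay, with a stated time of 72 h (on this read-out lower numbers stand for stronger inhibition and higher numbers for weaker inhibition), and compound 2 `COc1ccc(C(=O)Nc2cccc(-c3oc4cc(-c5ccc(F)cc5)ccc4c(=O)c3O)c2)c(F)c1` gives 24500 nM in this assay, the higher of the two numbers; the only step between them, a 3.7-fold higher number from compound 1 to compound 2 (0.57 log units; beyond the scatter), went with the change to 2-fluoro-4-methoxyphenyl on the carbonyl carbon. Compound 3 `COc1cc(OC)cc(C(=O)Nc2cccc(-c3oc4cc(-c5ccc(F)cc5)ccc4c(=O)c3O)c2)c1` is not yet measured. It differs from compound 2 in one place: 3,5-dimethoxyphenyl in place of 2-fluoro-4-methoxyphenyl on a carbonyl carbon. Within the data shown here, no measured pair shows this exact change, so the single step from compound 1 to compound 2 is the only guide, and it shows that a different pattern of groups on this ring can move the number by a modest amount. With one step as precedent, the direction is uncertain, and compound 3 is expected to land near compound 2, with the estimated step of a 1.2-fold lower number from compound 2 to compound 3 (0.09 log units; within the scatter). Compound 3 is therefore estimated at 20000 nM, within a range of 6000 nM to 65000 nM.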

Compound 3, half-maximal inhibitory concentration: 6250 nM
Beside the measured number, compound 3's estimate is 3.2-fold (0.51 log units) above it; measured number inside the range.
By their numbers in this assay, from the lowest: compounds 3 and 1 (each within the scatter of the next); then compound 2.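

In this assay the change on the carbonyl carbon gives a 3.9-fold lower number from compound 2 to compound 3 (0.59 log units; beyond the scatter) and so shows that a new pattern of groups on this ring can lower the number as well as raise it. The other new step, a 1.1-fold lower number from compound 1 to compound 3 (0.02 log units; within the scatter), shows that the 3,5-dimethoxyphenyl and 3-fluorophenyl groups cannot be told apart here, which leaves compound 2 as the one that stands apart with the highest number. No measurement shown here explains these differences.

The 2-fluoro-4-methoxyphenyl group differs from the 3,5-dimethoxyphenyl group in both its fluorine and its methoxy groups, so these compounds cannot show which difference goes with the change in number. As far as these compounds go, it also remains open how an amine or a carboxylic acid on this ring would fare.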